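Shortening the Chain on the Amide Nitrogen

The source may hold more compounds than are shown below. What is called first, only, known or untested is meant among the compounds shown, and "the series" means these compounds.

Compound 2 `CCC(CO)NC(=O)c1cc2cc(Br)ccc2oc1=N` has been measured in an assay on CHO cells for displacement of a labelled ligand from adenosine receptor A1 (Homo sapiens), read by scintillation counting, with a stated time of 60 min, tested at 10 uM (on this read-out lower numbers stand for less inhibition and higher numbers for more inhibition at the one concentration tested (going by the name of the read-out)), and gives 20%; compound 1 `N=c1oc2ccc(Br)cc2cc1C(=O)NCC(O)CO` gives 11% in this assay, and the step of a number 9 percentage points higher from compound 1 to compound 2 (within the scatter) lies within the scatter. Compound 3 `N=c1oc2ccc(Br)cc2cc1C(=O)NCCCO` has not yet been measured and differs from compound 2 in one place: 3-hydroxypropyl in place of 1-(hydroxymethyl)propyl on an amide-type nitrogen. Among the measured compounds shown here, the only measured step also exchanges one chain for another on the amide-type nitrogen and moved the number little, so the step of a number 3 percentage points lower from compound 2 to compound 3 (within the scatter) is expected to stay within the scatter. Compound 3 is therefore estimated at 17%, with a range from 4% to 32%.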

Compound 3, a percentage reported as inhibition, at one concentration (the size of the read-out at that concentration, not a potency): 32%
Compound 3: the middle estimate sits 15 percentage points below what was measured; the range from low to high includes it.
By their numbers in this assay, from the lowest: compounds 1 and 2 (each within the scatter of the next); then compound 3.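

In this assay, this position now shows its first step beyond the scatter: 3-hydroxypropyl in place of 1-(hydroxymethyl)propyl on the amide-type nitrogen gives a number 12 percentage points higher from compound 2 to compound 3 (beyond the scatter). Hydrogen in place of hydroxy on the chain gives a number 21 percentage points higher from compound 1 to compound 3 (beyond the scatter), so the choice of chain changes the number, though both steps are modest. Nothing available explains either step.

From the compounds shown here alone, whether a longer chain, or an amine in place of the hydroxy, would raise the number further stays open. These single-concentration numbers also give no potency.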